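Lengthening the Chain from Propyl toward a Longer Alkyl

The source may hold more compounds than are shown below. What is called first, only, known or untested is meant among the compounds shown, and "the series" means these compounds.

Compound 3 `CCCc1ccc(NC(=O)Nc2c(C(C)C)cccc2C(C)C)cc1` is the starting point. In an assay on isolated protein for inhibition of acyl-CoA:cholesterol acyltransferase (Oryctolagus cuniculus) (a lower number here means a stronger inhibitor, a higher number a weaker inhibitor), compound 3 gives 38 nM, the second highest of three numbers. Compound 1 `CCCCCCCCCCCCCc1ccc(NC(=O)Nc2c(C(C)C)cccc2C(C)C)cc1`, with a longer chain on the shared core, gives 11 nM, and compound 2 `Cc1ccc(NC(=O)Nc2c(C(C)C)cccc2C(C)C)cc1`, with a methyl group, gives 250 nM. Compound 4 `CCCCCCCCCCCc1ccc(NC(=O)Nc2c(C(C)C)cccc2C(C)C)cc1` differs from compound 3 by octyl in place of hydrogen on a saturated chain carbon, three bonds along the chain from an aromatic carbon. Among the compounds with values here, two measured steps bear on this change: a 6.6-fold lower number from compound 2 to compound 3 (0.82 log units; beyond the scatter), and a 3.5-fold higher number from compound 1 to compound 3 (0.54 log units; beyond the scatter). Both show a lower number as the chain grows, and compound 4 falls between compound 3 and compound 1 in chain length. A step of about a 2.7-fold lower number from compound 3 to compound 4 (0.43 log units; beyond the scatter) is therefore expected. Compound 4 is estimated at 14 nM, with a range from 6 nM to 35 nM.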

Compound 4, half-maximal inhibitory concentration: 9 nM
For compound 4 the middle estimate is 1.6-fold (0.19 log units) above the measured one; low and high end bracket the measured number.
By their numbers in this assay, from the lowest: compounds 4 and 1 (each within the scatter of the next); then compound 3; then compound 2.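

In this assay the number keeps falling as the chain grows on the shorter chains, with a 4.2-fold lower number from compound 3 to compound 4 (0.63 log units; beyond the scatter) and a 28-fold lower number from compound 2 to compound 4 (1.44 log units; beyond the scatter). That fall does not carry on to the longest chain shown, as a 1.2-fold lower number from compound 1 to compound 4 (0.09 log units; within the scatter) leaves compounds 4 and 1 indistinguishable. The same added ethyl therefore counts for much less on the long chain than on the short one: the same change on two cores in this assay, a 6.6-fold lower number (0.82 log units; beyond the scatter) from compound 2 to compound 3 and a 1.2-fold higher number (0.09 log units; within the scatter) from compound 4 to compound 1, 8.0-fold (0.91 log units) apart, beyond the scatter of two such steps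

Still open, going by these compounds, is where between propyl and undecyl the fall ends, for instance whether hexyl already matches compound 4. Also open, on these data alone, is whether a long chain bearing an amine would keep such low numbers.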